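Chloro to methoxy among three indistinguishable neighbours

This account rests on a few compounds, and the source may have more. Where it says the series, first, only, none or still open, it means among the compounds named here.

In a functional assay on CHO-TAX 5-6 cells (Cricetulus griseus) for antiproliferative activity, read by sulforhodamine B assay, with a stated time of 48 h (a higher number here means a weaker inhibitor, a lower number a stronger inhibitor), compound 1 `O=C1NCCN1c1ccc(S(=O)(=O)Nc2cccc(Br)c2)cc1` gives 76 nM, compound 2 `Cc1ccc(C)c(NS(=O)(=O)c2ccc(N3CCNC3=O)cc2)c1` gives 54 nM and compound 3 `O=C1NCCN1c1ccc(S(=O)(=O)Nc2cccc(Cl)c2)cc1` gives 58 nM. Compound 3 therefore stands in a tight group, since its gaps to both neighbours are no larger than the ordinary scatter of repeated measurements.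

Compound 4 `COc1cccc(NS(=O)(=O)c2ccc(N3CCNC3=O)cc2)c1` has not yet been measured. It keeps everything in compound 3 except for one group, with methoxy in place of chloro on an aromatic carbon, meta to a large group: methoxy in place of chloro on an aromatic carbon. Put another way, 3-chlorophenyl becomes 3-methoxyphenyl.

Among the measured compounds shown here, no measured step introduces methoxy, so the evidence is indirect. The nearest comparison is a 1.3-fold lower number from compound 1 to compound 3 (0.12 log units; within the scatter), with chloro in place of bromo on an aromatic carbon. The larger swaps of the whole substituted phenyl group give a 1.4-fold lower number from compound 1 to compound 2 (0.15 log units; within the scatter) and a 1.1-fold higher number from compound 2 to compound 3 (0.03 log units; within the scatter). All three steps stay within the scatter, so no step beyond the scatter is expected in this assay, although three compounds make a thin basis.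

The expected step is a 1.2-fold higher number from compound 3 to compound 4 (0.08 log units; within the scatter). Compound 4 is estimated at 70 nM, with an expected range from 30 nM to 170 nM.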

Compound 4, half-maximal inhibitory concentration: 200 nM
The estimate for compound 4 lay 2.9-fold (0.46 log units) below the measured number; measured number above the stated range.
By their numbers in this assay, from the lowest: compounds 2, 3 and 1 (each within the scatter of the next); then compound 4.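

Until now, every exchange on this phenyl ring stayed within the scatter, so the ring could have seemed tolerant of whatever was placed on it. In this assay, among the compounds shown here, methoxy is the first change to go beyond the scatter, with a 3.4-fold higher number from compound 3 to compound 4 (0.54 log units; beyond the scatter) and the same direction against the other two compounds, namely a 2.6-fold higher number from compound 1 to compound 4 (0.42 log units; beyond the scatter) and a 3.7-fold higher number from compound 2 to compound 4 (0.57 log units; beyond the scatter). Compound 4 is thus a weaker inhibitor than all three earlier compounds, which shows that this position does respond to the group it carries, even though chloro and bromo cannot be told apart there, and no measurement at hand explains the loss.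

The swap adds one heavy atom and one hydrogen-bond acceptor together, so the compounds shown cannot say which of these goes with the higher number. A hydroxy group or an ethyl group in the same place would help to separate the two, and an amine would show whether other groups joined to the ring through a heteroatom behave like methoxy.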